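This account rests on a few compounds, and the source may have more. Where it says the series, first, only, none or still open, it means among the compounds named here.

The account begins with two measured compounds that share a coumarin-like core only in the sense that both carry a bicyclic lactone; their substituents differ entirely. Compound 1, `Cc1cc(=O)oc2cc(Sc3cccc(Cl)n3)ccc12`, gives 5890 nM in a functional assay on HUVEC cells (Homo sapiens) for antiproliferative activity, read by MTT assay, with a stated time of 48 h; on this read-out higher numbers stand for weaker inhibition and lower numbers for stronger inhibition. Compound 2, `O=c1ccc2ccc(Oc3no[n+]([O-])c3S(=O)(=O)c3ccccc3)cc2o1`, gives 6750 nM in the same assay, the highest of the two numbers on hand; its nearest neighbour is compound 1, whose number is within the scatter, so the two compounds cannot be placed in any order on this read-out.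

The next compound, compound 3, `Cc1cc(=O)oc2cc(Oc3no[n+]([O-])c3S(=O)(=O)c3ccccc3)ccc12`, differs from compound 2 in a single place: methyl in place of hydrogen on an aromatic carbon. Among the compounds with values here, no step between measured compounds is available to calibrate this change, so the expectation rests on compound 1 and compound 2 alone, whose values sit close together although one carries the methyl and the other does not. The step from compound 2 to compound 3 is therefore expected to be a 1.1-fold lower number from compound 2 to compound 3 (0.05 log units; within the scatter), that is, nothing beyond the scatter in either direction. Compound 3 is estimated at 6000 nM, with a plausible range from 2500 nM to 15000 nM.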

Compound 3, half-maximal inhibitory concentration: 5430 nM
Beside the measured number, compound 3's estimate is 1.1-fold (0.04 log units) above it, within the range that was stated.
By their numbers in this assay, from the lowest: compounds 3, 1 and 2 (each within the scatter of the next).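

In this assay, placing a methyl in place of hydrogen on the aromatic carbon opposite the ring oxygen gives a 1.2-fold lower number from compound 2 to compound 3 (0.09 log units; within the scatter). Within the data shown here, this is the first step in the account that isolates one change with the rest of the structure held constant, which the comparison of compound 1 with compound 2 could not do, since those two differ in more than one place. On this read-out, the added methyl at this position therefore produces no difference that can be told apart from the scatter, and no evidence on the reason for this result is at hand.

As far as these compounds go, whether a larger group on this same carbon, such as an ethyl or a longer chain, or a different kind of group, such as an amine or a carboxylic acid, would shift the number beyond the scatter remains open. Among these compounds, also open is whether a methyl at this position would give a similarly small step with a different substituent on the other side of the core, such as the one carried by compound 1.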